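Fluoro for hydrogen on two aryl piperazine ether cores

The source may report more compounds than this note shows. Statements on the series, on what has been measured and on what is new or still open speak of the compounds shown alone.

Compound 1 `c1ccc(N2CCN(CCCCCOc3ccc4c(c3)CCC4)CC2)cc1` and compound 2 `Fc1ccc(N2CCN(CCCCCOc3ccc4c(c3)CCC4)CC2)cc1` share one core; compound 3 `c1ccc(N2CCN(CCCOc3cccc4c3CCC4)CC2)cc1` and compound 4 `Fc1ccc(N2CCN(CCCOc3cccc4c3CCC4)CC2)cc1` share another. The difference between the two cores is not broken down here. In a functional assay on the whole organism for inhibition, with Mus musculus as the target, at a dose of 25 mg/kg by the oral route (a lower number here means less inhibition, a higher number more inhibition at the dose given (going by the name of the read-out)), compound 1 gives 25% and compound 2 gives 71%; the change between them, (fluoro in place of hydrogen on an aromatic carbon), made the step of a number 46 percentage points higher from compound 1 to compound 2 (beyond the scatter). In this assay compound 3 gives 33%, which lies close to compound 1. Compound 4 carries the same change on the other core, (fluoro in place of hydrogen on an aromatic carbon), at the same place. The change has been measured once only, so the expectation is kept a little smaller than that precedent. For compound 4 the expected step in this assay is a number 32 percentage points higher from compound 3 to compound 4 (beyond the scatter), resting on the step of a number 46 percentage points higher from compound 1 to compound 2 (beyond the scatter). Compound 4 is estimated at 65%, between 45% and 85%.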

Compound 4, a percentage reported as inhibition, in the whole organism at one dose (the size of the read-out at that dose, not a potency): 25%
Compound 4: the middle estimate sits 40 percentage points above what was measured; the measured number lies below the stated range.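

In this assay the change from phenyl to 4-fluorophenyl does not carry from one core to the other: the same change on two cores in this assay, a number 46 percentage points higher (beyond the scatter) from compound 1 to compound 2 and a number 8 percentage points lower (within the scatter) from compound 3 to compound 4, 54 percentage points apart, beyond the scatter of two such steps

On the core of compound 3, the change gives a number 8 percentage points lower from compound 3 to compound 4 (within the scatter) and so shows no gain at this dose. With a single pair on each core, the data show that the result depends on the core, but not which part of the difference between the cores decides it, nor how either pair would behave at another dose. The compounds shown leave open whether chloro or methoxy in the same place would follow compound 2 or compound 4 on either core. Also open, from the compounds shown here alone, is whether the fluoro gain on the core of compound 1 survives with a shorter chain.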